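Back from Ethyl to an Aromatic Ring on the Nitrogen

This account rests on a few compounds, and the source may have more. Where it says the series, first, only, none or still open, it means among the compounds named here.

The series shares one core, seen in compound 1 `O=C(NCCCCc1ccccc1)c1cccc(C2SCC(=O)N2c2cccc(F)c2)c1`, which in a functional assay on HOS-TE85 cells (Homo sapiens) for inhibition, read by CCK-8 assay, with a stated time of 72 h (on this read-out lower numbers stand for stronger inhibition and higher numbers for weaker inhibition), gives 32.4 nM. Compound 2 `CCOc1ccccc1N1C(=O)C(C)SC1c1cccc(C(=O)NCCCCc2ccccc2)c1` bears an ethoxyphenyl on the ring nitrogen and a methyl on the ring; in this assay compound 2 gives 71.6 nM. Compound 3 `CCN1C(=O)CSC1c1cccc(C(=O)NCCCCc2ccccc2)c1` carries an ethyl group on the ring nitrogen. In this assay compound 3 gives > 1000 nM, which is a limit of the assay and not a number, so compound 3 stands at the limit of > 1000 nM in this assay, at which 1 of the 3 values shown sits, among the values shown. Among the measured compounds shown here, the one measured step bearing on the present change is an at least 30-fold higher number from compound 1 to compound 3 (1.48 log units; beyond the scatter), a large loss when the aromatic ring on the nitrogen gave way to ethyl. Compound 4 `O=C(NCCCCc1ccccc1)c1cccc(C2SCC(=O)N2c2cnccn2)c1` moves the other way: pyrazin-2-yl in place of ethyl on an amide-type nitrogen in a ring. Since this restores an aromatic ring at the position that produced an at least 30-fold higher number from compound 1 to compound 3 (1.48 log units; beyond the scatter), a large step toward stronger inhibition is expected, though the pyrazin-2-yl is not the 3-fluorophenyl of compound 1, so compound 4 is not expected to match compound 1. Compound 4 is therefore estimated at 150 nM, within 40 nM to 800 nM, an expected step of an at least 6.6-fold lower number from compound 3 to compound 4 (0.82 log units; beyond the scatter).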

Compound 4, half-maximal inhibitory concentration: > 1000 nM
Compound 4 was reported as a limit; the forecaster's own chance of this, stated with the estimate: 15%; middle value at least 6.6-fold (0.82 log units) from the limit.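

In this assay, pyrazin-2-yl in place of 3-fluorophenyl gives an at least 30-fold higher number from compound 1 to compound 4 (1.48 log units; beyond the scatter), so an aromatic ring on this amide-type nitrogen is not enough by itself to keep the number of compound 1. Between compound 1 and compound 4, the kind of aromatic ring at this position makes a large difference, not merely its presence. The step between ethyl and pyrazin-2-yl cannot be read, as both ends are limits and not numbers, and compound 4 now stands at the same limit as compound 3: the limit of > 1000 nM in this assay, at which 2 of the 4 values shown sit.

From the compounds shown here alone, how far compound 3 and compound 4 lie past that limit stays open. Also open, going by these compounds, is whether a plain phenyl or a pyridin-2-yl on this nitrogen would read closer to compound 1 or to compound 4.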